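Aryl groups on the ring nitrogen: toward compound 4

The compounds below may be only part of what the source reports. "The series", "measured", "known", "first", "only" and "open" are said of these compounds alone.

Compound 1 `N#Cc1cccc(-n2cc(COc3cccc(NC(=O)Nc4ccc(Cl)c(C(F)(F)F)c4)c3)nn2)c1` gives 2760 nM in a functional assay on HepG2 cells (Homo sapiens) for inhibition, read by MTT assay, with a stated time of 72 h; a higher number here means a weaker inhibitor, a lower number a stronger inhibitor. Compound 2 `N#Cc1ccc(-n2cc(COc3cccc(NC(=O)Nc4ccc(Cl)c(C(F)(F)F)c4)c3)nn2)cc1` gives 2980 nM in this assay, and compound 3 `O=C(Nc1cccc(OCc2cn(-c3cccc(F)c3)nn2)c1)Nc1ccc(Cl)c(C(F)(F)F)c1` gives 2120 nM. Of these three numbers compound 1 stands second highest; its nearest is compound 2, with a 1.1-fold higher number from compound 1 to compound 2 (0.03 log units; within the scatter), and its furthest is compound 3, with a 1.3-fold lower number from compound 1 to compound 3 (0.11 log units; within the scatter). The remaining pair shows a 1.4-fold lower number from compound 2 to compound 3 (0.15 log units; within the scatter). All three steps lie within the scatter, so the three aryl groups on the ring nitrogen of the shared core cannot be told apart on these numbers.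

Compound 4 `O=C(Nc1cccc(OCc2cn(-c3ccccc3C(F)(F)F)nn2)c1)Nc1ccc(Cl)c(C(F)(F)F)c1` differs from compound 1 as follows: 2-(trifluoromethyl)phenyl in place of 3-cyanophenyl on an aromatic nitrogen. The measured steps that bear on this change are the three aryl swaps on the same nitrogen just given, each within the scatter. No step beyond the scatter is therefore expected in this assay for compound 4, in either direction. For compound 4 the estimated value is 2500 nM, with a range from 1200 nM to 5500 nM. This estimate means an expected step of a 1.1-fold lower number from compound 1 to compound 4 (0.04 log units; within the scatter).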

Compound 4, half-maximal inhibitory concentration: 2320 nM
The estimate for compound 4 lay 1.1-fold (0.03 log units) above the measured number; the measured number falls inside the stated range.
By their numbers in this assay, from the lowest: compounds 3, 4, 1 and 2 (each within the scatter of the next).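

In this assay, the 2-(trifluoromethyl)phenyl group of compound 4 stays within the scatter of all three earlier aryl groups: a 1.2-fold lower number from compound 1 to compound 4 (0.08 log units; within the scatter), a 1.1-fold higher number from compound 3 to compound 4 (0.04 log units; within the scatter) and a 1.3-fold lower number from compound 2 to compound 4 (0.11 log units; within the scatter). The insensitivity at this aromatic nitrogen now extends to a group with more heavy atoms than 3-cyanophenyl and no hydrogen-bond acceptor, with its substituent at the 2-position named in 2-(trifluoromethyl)phenyl rather than the 3- and 4-positions of the earlier groups. No supporting measurement bears on why the number stays flat across these four aryl groups.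

Going by these compounds, it remains open whether any group on this nitrogen can move the number beyond the scatter. A phenyl ring carrying an amine or a carboxylic acid, or a longer alkyl chain in place of the aryl ring, would test this.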